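Cytotoxicity limits across a nitro-sulfone benzamide series

The source may report more compounds than this note shows. Statements on the series, on what has been measured and on what is new or still open speak of the compounds shown alone.

Measured compounds:
- compound 1, `CC1CCN(C(=O)CCCNC(=O)c2ccc(S(C)(=O)=O)c([N+](=O)[O-])c2)CC1`: in an ADME assay on HepG2 cells (Homo sapiens) for cytotoxicity, read by CellTiter-Glo and ATP content, with a stated time of 72 h (on this read-out lower numbers stand for an effect already at smaller amounts and higher numbers for an effect only at larger amounts of compound), compound 1 gives > 27000 nM
- compound 2, `CS(=O)(=O)c1ccc(C(=O)NCCCC(=O)N2CCC(c3ccccc3)CC2)cc1[N+](=O)[O-]`: compound 2 gives > 27000 nM
- compound 3, `CN1CCN(C(=O)CNC(=O)c2ccc(S(C)(=O)=O)c([N+](=O)[O-])c2)CC1`: compound 3 gives > 27000 nM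

The value of compound 1 is a limit of the assay, not a number. The same is true of compound 2 and of compound 3, so compound 1 stands at the common limit with every other value shown (the limit of > 27000 nM in this assay, at which 3 of the 3 values shown sit). Among the measured compounds shown here, the single step between measured neighbours, a step that the two limits leave unreadable from compound 1 to compound 2, phenyl in place of methyl on a saturated ring carbon, remains unreadable, both of its ends being limits.

Compound 4, `CN(Cc1ccccc1F)C(=O)CCCNC(=O)c1ccc(S(C)(=O)=O)c([N+](=O)[O-])c1`, differs from compound 1 by (2-fluorobenzyl)(methyl)amino in place of 4-methylpiperidin-1-yl on a carbonyl carbon. For the measured compounds named here, no measured step offers a readable size for this change, so no step beyond the scatter is expected in this assay. The estimate for compound 4 is 40000 nM, with an expected range from 20000 nM to 100000 nM. That estimate corresponds to an expected step that the limit leaves unreadable from compound 1 to compound 4, most likely reported again as a limit.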

Compound 4, half-maximal effective concentration: > 27000 nM
Compound 4 ended at the assay's limit (the forecaster's own chance of this, stated with the estimate: 85%); the middle value is on the limit's open side.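

Compound 1 and compound 4 are both reported only as limits, so the step between them cannot be read. The compounds shown leave open whether any of these changes shifts the read-out, since all sit at one value: the limit of > 27000 nM in this assay, at which 4 of the 4 values shown sit.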